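The source may hold more compounds than are shown below. What is called first, only, known or untested is meant among the compounds shown, and "the series" means these compounds.

Compound 1 `O=C(/C(=C/c1ccccc1)CCl)c1ccccc1`, compound 2 `O=C(/C(=C/c1ccc(Cl)cc1)CCl)c1ccccc1` and compound 3 `O=C(/C(=C/c1ccc(Cl)cc1Cl)CCl)c1ccccc1` share one core. In a functional assay on SW1573 cells (Homo sapiens) for inhibition, read by sulforhodamine B assay, with a stated time of 48 h (on this read-out higher numbers stand for weaker inhibition of growth and lower numbers for stronger inhibition of growth), compound 1 gives 3600 nM, compound 2 gives 3900 nM and compound 3 gives 3800 nM. Compound 2 holds the highest of the three numbers, yet all three sit within the scatter of one another: a 1.1-fold higher number from compound 1 to compound 2 (0.03 log units; within the scatter) and a 1.0-fold lower number from compound 2 to compound 3 (0.01 log units; within the scatter). Compound 4 `CC(=O)OC/C(=C\c1ccc(Cl)cc1)C(=O)c1ccccc1` differs from compound 2 by acetoxy in place of chloro on a saturated chain carbon bound to a double-bonded chain carbon. Neither measured step concerns this part of the chain; both are chloro in place of hydrogen on an aromatic carbon and both are within the scatter, so they offer no guide to direction. Within the data shown here, with no step of this kind on record, the expected step is a 1.0-fold higher number from compound 2 to compound 4 (0.01 log units; within the scatter), a wide range around no change. Compound 4 is estimated at 4000 nM, range 1300 nM to 12000 nM.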

Compound 4, concentration for 50% growth inhibition: 2600 nM
For compound 4 the middle estimate is 1.5-fold (0.19 log units) above the measured one; the range from low to high includes it.
By their numbers in this assay, from the lowest: compounds 4, 1, 3 and 2 (each within the scatter of the next).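

Chloromethyl to acetoxymethyl is the first change on record at this saturated chain carbon bound to a double-bonded chain carbon, and in this assay it gives a 1.5-fold lower number from compound 2 to compound 4 (0.18 log units; within the scatter). In this pair, the chloro is therefore not required to keep growth inhibition at this level, since acetoxy takes its place without a step beyond the scatter. Nothing available here bears on why the two groups read alike.

As far as these compounds go, whether an amine, a hydroxyl or a carboxylic acid at this carbon would also stay within the scatter remains open. So does whether acetoxy would read the same on the core of compound 1 or compound 3.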